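Ester variants of the shared core: stability notes

The compounds below may be only part of what the source reports. "The series", "measured", "known", "first", "only" and "open" are said of these compounds alone.

Measured compounds:
compound 1 `Cc1oc(=O)oc1COC(=O)C1=C(S[C@@H]2CN[C@H](C(=O)Nc3cccc(C(=O)OCc4oc(=O)oc4C)c3)C2)[C@H](C)[C@@H]2[C@@H]([C@@H](C)O)C(=O)N12` — > 95%
compound 2 `CC(C)C(=O)OCOC(=O)C1=C(S[C@@H]2CN[C@H](C(=O)Nc3cccc(C(=O)O)c3)C2)[C@H](C)[C@@H]2[C@@H]([C@@H](C)O)C(=O)N12` — > 95%

In an ADME assay for metabolic stability, read by LC-MS, with a stated time of 3 h, at pH 6.5, tested at 50 uM (on this read-out lower numbers stand for a less stable compound and higher numbers for a more stable compound), compound 1 gives > 95%, which is a limit of the assay and not a number. Compound 2 gives > 95% in this assay, again a limit rather than a number. Both results sit at the limit of > 95% in this assay, at which 2 of the 2 values shown sit, so compound 2 stands at the top of what this assay reports, with nothing to separate it from compound 1.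

Compound 3 `C[C@@H](O)[C@H]1C(=O)N2C(C(=O)OCOC(=O)C(C)(C)C)=C(S[C@@H]3CN[C@H](C(=O)Nc4cccc(C(=O)O)c4)C3)[C@H](C)[C@H]12` is not yet measured. It differs from compound 2 by methyl in place of hydrogen on a saturated chain carbon bound to a carbonyl carbon and two saturated chain carbons. Within the data shown here, no measured pair carries this change, so the size of the step cannot be read from the data. With compound 2 already at the reporting limit, the expected step from compound 2 to compound 3 in this assay is a step that the limit leaves unreadable from compound 2 to compound 3, that is none beyond the scatter. Compound 3 is therefore estimated at 96%, within 88% to 100%.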

Compound 3, percent of the compound remaining: > 95%
Compound 3 gave a limit, no number; the forecaster's own chance of this, stated with the estimate: 80%; the middle value is on the limit's open side.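

Compound 3 gives > 95% in this assay, a limit and not a number. With compound 2 also at a limit, no step between compound 2 and compound 3 can be read: the limit of > 95% in this assay, at which 3 of the 3 values shown sit.

The compounds shown leave open whether isopropyl to tert-butyl changes stability in this assay at all.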